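A few compounds are considered here, and "the series" means these few. Any claim that something is new, unique, unknown or untested is made for them only; others in the source may bear on it.

Measured in a functional assay on MDA-MB-231 cells (Homo sapiens) for inhibition, read by MTT assay, with stated times of 18 h and 4 h; a lower number here means a stronger inhibitor, a higher number a weaker inhibitor 
- compound 1 `CCCOP(=O)(O)OCCSC(=S)N1CCCCC1` gives 68000 nM
- compound 2 `CCCCCCCCCCOP(=O)(O)OCCSC(=S)N1CCCC1` gives 67000 nM

Compound 2 and compound 1 lie within the usual scatter of each other, so neither ranks ahead. Compound 3 `CCCOP(=O)(O)OCCSC(=S)N1CCCC1` awaits measurement. It differs from compound 2 by one change: hydrogen in place of heptyl on a saturated chain carbon, three bonds along the chain from an oxygen on an unsaturated carbon. Going by the values given here, no measured step shows the effect of this change. With compound 1 at 68000 nM and compound 2 at 67000 nM, no step beyond the scatter is expected in this assay. The estimated change is a 1.0-fold higher number from compound 2 to compound 3 (0.01 log units; within the scatter). For compound 3 the estimate is 68000 nM, with an expected range of 35000 nM to 130000 nM.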

Compound 3, half-maximal inhibitory concentration: 67000 nM
Estimate against measurement, compound 3: 1.0-fold (0.01 log units) above, within the range that was stated.
By their numbers in this assay, from the lowest: compounds 2, 3 and 1 (each within the scatter of the next).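

In this assay, hydrogen in place of heptyl on a saturated chain carbon, three bonds along the chain from an oxygen on an unsaturated carbon, gives no change at the digits printed from compound 2 to compound 3 (within the scatter) and so does not separate these two compounds. Pyrrolidin-1-yl in place of piperidin-1-yl on a thiocarbonyl carbon gives a 1.0-fold lower number from compound 1 to compound 3 (0.01 log units; within the scatter) and does not separate that pair either. No supporting data are available to explain these results.
As far as these compounds go, whether an amine or a carboxylic acid at the chain position would give a different number remains open. So does the effect of a morpholine ring on the thiocarbonyl carbon.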